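Swapping the Aryl Group on a Weakly Active Series

The source may hold more compounds than are shown below. What is called first, only, known or untested is meant among the compounds shown, and "the series" means these compounds.

Compound 3 `COc1cc2ncnc(NCc3cccc(NC(=O)Nc4ccccc4C)c3)c2cc1OC` has been tested in a functional assay on HepG2 cells (Homo sapiens) for antiproliferative activity, read by MTT assay; a higher number here means a weaker inhibitor, a lower number a stronger inhibitor. In this assay compound 3 reaches only the limit > 50000 nM, so no number is known for it. It is one of the compounds at the limit of > 50000 nM in this assay, at which 1 of the 3 values shown sits. The step to compound 4 `COc1cc2ncnc(NCc3cccc(NC(=O)Nc4ccc(C(C)(C)C)cc4)c3)c2cc1OC` is 4-(tert-butyl)phenyl in place of 2-methylphenyl on an amide-type nitrogen. Two other measured compounds share the core of compound 1 rather than the core of compound 3. Compound 1 `CC(C)(C)c1ccc(NC(=O)Nc2cccc(CNc3ncnc4ccccc34)c2)cc1` gives 17000 nM in this assay. Compound 2 `O=C(Nc1cccc(CNc2ncnc3ccccc23)c1)Nc1cccc(C(F)(F)F)c1` gives 40000 nM in this assay. Within the data shown here, the single measured step, a 2.4-fold higher number from compound 1 to compound 2 (0.37 log units; beyond the scatter), also swaps the aryl group on the amide-type nitrogen, and the 4-(tert-butyl)phenyl partner is the one with the lower number. Among the measured compounds shown here, no measured step joins the core of compound 3 to the core of compound 1; compound 1 and compound 3 show only that one sits at a number and the other at a limit. For compound 4 the expected step is an at least 1.4-fold lower number from compound 3 to compound 4 (0.15 log units; that floor lies within the scatter), a move to a lower number, but a modest one. Compound 4 is therefore estimated to give 35000 nM in this assay, with a range from 12000 nM to 100000 nM.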

Compound 4, half-maximal inhibitory concentration: 6850 nM
Beside the measured number, compound 4's estimate is 5.1-fold (0.71 log units) above it, and the stated range ends above it.
By their numbers in this assay, from the lowest: compound 4; then compound 1; then compound 2. At a limit, above all of these: compound 3.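

Changing the aryl group on the amide-type nitrogen matters on the core of compound 3 as well, and the swap of 2-methylphenyl for 4-(tert-butyl)phenyl gives an at least 7.2-fold lower number from compound 3 to compound 4 (0.86 log units; beyond the scatter). Among these compounds, until now, the only measured change at this place was on the core of compound 1; on both cores, the 4-(tert-butyl)phenyl partner has the lower number, although a different group stands opposite it in each pair. Compound 3 carries a limit and not a number, so this step is only a floor: the limit of > 50000 nM in this assay, at which 1 of the 4 values shown sits.

From the compounds shown here alone, whether 2-methylphenyl and 4-(tert-butyl)phenyl would differ in the same way on the core of compound 1 stays open. So does the outcome of putting an amine or a carboxylic acid in place of the tert-butyl group.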